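A ring swap on compound 3

A few compounds are considered here, and "the series" means these few. Any claim that something is new, unique, unknown or untested is made for them only; others in the source may bear on it.

Measured so far in an ADME assay on Huh-7 cells (Homo sapiens) for cytotoxicity, with a stated time of 72 h; a higher number here means that more compound is tolerated, a lower number that less compound is tolerated
Compound 1 `CCCS(=O)(=O)Nc1ccc2c(c1)S(=O)(=O)N=C(c1c(O)c(-c3cccs3)nn(CCC(C)C)c1=O)N2` reads > 1000 nM (a limit)
Compound 2 `CC(C)CCn1nc(-c2cccs2)c(O)c(C2=NS(=O)(=O)c3cc(S(C)(=O)=O)ccc3N2)c1=O` reads "not determined" (no result reported) (no number)
Compound 3 `CC(C)CCn1nc(-c2ccn(C)c2)c(O)c(C2=NS(=O)(=O)c3cc(NS(C)(=O)=O)ccc3N2)c1=O` reads > 1000 nM (a limit)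

Compound 3 stands at a limit and not at a number: the limit of > 1000 nM in this assay, at which 2 of the 3 values shown sit, is all that is known of it. The change (cyclopent-1-en-1-yl)methyl in place of 1-methyl-1H-pyrrol-3-yl on an aromatic carbon puts (cyclopent-1-en-1-yl)methyl in place of 1-methyl-1H-pyrrol-3-yl on an aromatic carbon, giving compound 4 `CC(C)CCn1nc(CC2=CCCC2)c(O)c(C2=NS(=O)(=O)c3cc(NS(C)(=O)=O)ccc3N2)c1=O` as the result. Among the measured compounds shown here, no measured step bears on this change, and no shift beyond the usual scatter is expected in this assay here. The estimate means a step that the limit leaves unreadable from compound 3 to compound 4 as the expected step, within the scatter. For compound 4 the expected value is 1500 nM with an estimated range of 800 nM to 3000 nM overall.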

Compound 4, half-maximal cytotoxic concentration: > 33000 nM
Compound 4 ended at the assay's limit; the forecaster's own chance of this, stated with the estimate: 85%; middle value at least 22-fold (1.34 log units) from the limit.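

Among the compounds shown here, compound 3 and compound 4 are both known only as limits, so no step between them can be read. The compounds shown leave open where the half-maximal cytotoxic concentration of either compound actually lies.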